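A Trifluoromethyl Group Added to Compound 3

A few compounds are considered here, and "the series" means these few. Any claim that something is new, unique, unknown or untested is made for them only; others in the source may bear on it.

In a functional assay on LNCaP cells (Homo sapiens) for antiproliferative activity, read by propidium iodide staining, with a stated time of 96 h (on this read-out lower numbers stand for stronger inhibition and higher numbers for weaker inhibition), compound 3 `CC(O)(COc1ccc(C#N)cc1)C(=O)Nc1cccc(S(F)(F)(F)(F)F)c1` gives 30000 nM as its value. Two close relatives lie within the scatter of it: compound 1 `CC(O)(COc1cccc(C(F)(F)F)c1)C(=O)Nc1cccc(S(F)(F)(F)(F)F)c1` gives 28800 nM as its value, and compound 2 `CC(O)(COc1ccccc1C(F)(F)F)C(=O)Nc1cccc(S(F)(F)(F)(F)F)c1` gives 26300 nM as its value. All three share the core and differ only in the group on the oxygen.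

Compound 4 `CC(O)(COc1ccc(C#N)cc1C(F)(F)F)C(=O)Nc1cccc(S(F)(F)(F)(F)F)c1` changes compound 3 in one place, with trifluoromethyl in place of hydrogen on an aromatic carbon, ortho to a large group and meta to a cyano group. The change in full is trifluoromethyl in place of hydrogen on an aromatic carbon and it leaves compound 4 carrying both the cyano group of compound 3 and the trifluoromethyl group of compound 2.

Going by the values given here, no measured compound holds both groups, so the evidence is indirect. It comes from three swaps: a 1.1-fold higher number from compound 2 to compound 3 (0.06 log units; within the scatter), a 1.1-fold lower number from compound 1 to compound 2 (0.04 log units; within the scatter) and a 1.0-fold higher number from compound 1 to compound 3 (0.02 log units; within the scatter), all within the scatter. On this evidence, no step beyond the scatter is expected in this assay and the estimated step is a 1.2-fold lower number from compound 3 to compound 4 (0.08 log units; within the scatter), which has no meaningful direction. For compound 4 the estimated value is 25000 nM, with an expected range of 10000 nM to 50000 nM as the outcome.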

Compound 4, half-maximal inhibitory concentration: 16400 nM
Compound 4: the middle estimate sits 1.5-fold (0.18 log units) above what was measured; low and high end bracket the measured number.
By their numbers in this assay, from the lowest: compounds 4, 2, 1 and 3 (each within the scatter of the next).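

In this assay, the ring position ortho to a large group and meta to a cyano group accepts a trifluoromethyl group with a 1.8-fold lower number from compound 3 to compound 4 (0.26 log units; within the scatter), so filling this place in the cyano compound brings no real change in the number. Seen from the other side, adding cyano to the ring that already carries trifluoromethyl gives a 1.6-fold lower number from compound 2 to compound 4 (0.21 log units; within the scatter), which shows that the two groups can share one ring while compound 4 stays within the scatter of both single-group relatives. Having both groups together therefore gives no clear gain over having either one alone, and no measurement at hand explains why the numbers stay this close.

The compounds shown say nothing about whether a different kind of group at this same place, such as an amine, a carboxylic acid or a longer chain, would move the number beyond the scatter. They also leave open whether trifluoromethyl would behave the same way on a ring with something other than cyano, or on a core other than the shared one.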